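From 3-methylbenzyl to (naphthalen-2-yl)methyl in the series

The compounds below may be only part of what the source reports. "The series", "measured", "known", "first", "only" and "open" are said of these compounds alone.

Measured in a functional assay on BGC-823 cells (Homo sapiens) for inhibition, read by MTT assay, with a stated time of 72 h (a higher number here means a weaker inhibitor, a lower number a stronger inhibitor), so far:
compound 1 `Cc1cccc(CN2CCc3ncn(COCc4ccccc4)c3/C(=C/c3ccccc3)C2=O)c1` gives 14600 nM
compound 2 `COc1ccc(CN2CCc3ncn(COCc4ccccc4)c3/C(=C/c3ccccc3)C2=O)cc1` gives 71600 nM
compound 3 `COc1cc(/C=C2\C(=O)N(Cc3ccccc3)CCc3ncn(COCc4ccccc4)c32)cc(OC)c1OC` gives 12900 nM

Compound 1 lies within the scatter of compound 3, and compound 2 has a clearly higher number than either. Compound 4 `O=C1/C(=C\c2ccccc2)c2c(ncn2COCc2ccccc2)CCN1Cc1ccc2ccccc2c1` carries one change from compound 1: naphthalen-2-yl in place of 3-methylphenyl on a saturated chain carbon bound to an amide-type nitrogen in a ring is the full difference. Within the data shown here, the only measured step at this place is a 4.9-fold higher number from compound 1 to compound 2 (0.69 log units; beyond the scatter) and it is modest but beyond the scatter. It shows that this place can move the number, yet it involves a different group, so it gives only a weak lean upward. The expected step is a 1.5-fold higher number from compound 1 to compound 4 (0.18 log units; within the scatter) in this assay and it is not expected to clear the scatter. For compound 4 the estimated value is 22000 nM with an expected range from 7000 nM to 70000 nM in this estimate.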

Compound 4, half-maximal inhibitory concentration: 93300 nM
Estimate against measurement, compound 4: 4.2-fold (0.63 log units) below, and the stated range ends below it.
By their numbers in this assay, from the lowest: compounds 3 and 1 (each within the scatter of the next); then compounds 2 and 4 (each within the scatter of the next).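

In this assay, naphthalen-2-yl gives a 6.4-fold higher number from compound 1 to compound 4 (0.81 log units; beyond the scatter) and so shows that the earlier rise at this place is not confined to 4-methoxyphenyl. Set against 4-methoxyphenyl, naphthalen-2-yl gives a 1.3-fold higher number from compound 2 to compound 4 (0.11 log units; within the scatter) and so the two groups cannot be told apart here, while 3-methylphenyl keeps the lowest number of the three. No supporting data at hand bear on this result.

Open, on these data alone, is whether a pyridinyl or a phenyl carrying a carboxylic acid at this place would stay near compound 1 or also move upward.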